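The compounds below may be only part of what the source reports. "The series", "measured", "known", "first", "only" and "open" are said of these compounds alone.

Compound 3, with structure `CCCCC(C)(O)CC(=O)O[C@H](CC=C(C)C)C1=CC(=O)c2c(O)ccc(O)c2C1=O`, gives 76500 nM in a functional assay on DU-145 cells (Homo sapiens) for cytotoxicity, read by MTT assay (on this read-out higher numbers stand for weaker inhibition and lower numbers for stronger inhibition), and so holds the highest number of the three measured compounds. Compound 1 (`CC(C)=CC[C@@H](OC[C@H](C)O)C1=CC(=O)c2c(O)ccc(O)c2C1=O`) gives 24500 nM, and compound 2 (`COCCO[C@H](CC=C(C)C)C1=CC(=O)c2c(O)ccc(O)c2C1=O`) gives 43200 nM; the step of a 3.1-fold higher number from compound 1 to compound 3 (0.49 log units; beyond the scatter) lies beyond the scatter, whereas a 1.8-fold higher number from compound 2 to compound 3 (0.25 log units; within the scatter) and a 1.8-fold higher number from compound 1 to compound 2 (0.25 log units; within the scatter) do not. Compound 4, `CC(C)=CC[C@@H](OC(=O)C1CCCOC1)C1=CC(=O)c2c(O)ccc(O)c2C1=O`, keeps the core and the ester link of compound 3 but changes the acyl part: oxan-3-yl in place of 2-hydroxy-2-methylhexyl on a carbonyl carbon. The measured steps, all at this side chain, moved the number only by small to modest amounts, so compound 4 is expected to show a step of a 1.4-fold lower number from compound 3 to compound 4 (0.14 log units; within the scatter), within the scatter. The estimate for compound 4 is therefore 55000 nM, between 22000 nM and 130000 nM.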

Compound 4, half-maximal inhibitory concentration: 29700 nM
Compound 4: the middle estimate sits 1.9-fold (0.27 log units) above what was measured, and the stated range covers the measured number.
By their numbers in this assay, from the lowest: compounds 1, 4, 2 and 3 (each within the scatter of the next, the first and the last beyond it).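

Putting oxan-3-yl in place of 2-hydroxy-2-methylhexyl on a carbonyl carbon gives a 2.6-fold lower number from compound 3 to compound 4 (0.41 log units; beyond the scatter) and so shows that a change within the acyl part alone, with the ester link kept, can move the number beyond the scatter. The steps of a 1.5-fold lower number from compound 2 to compound 4 (0.16 log units; within the scatter) and a 1.2-fold higher number from compound 1 to compound 4 (0.08 log units; within the scatter) both stay within the scatter, so (oxan-3-yl)carbonyl reads no differently here from 2-methoxyethyl or 2-hydroxypropyl on that oxygen. No measurement shown accounts for the step from the open chain to the ring.

On these data alone, whether an amine, a carboxylic acid or a longer chain on this carbonyl carbon would shift the number further remains open. So does whether the ring or the lost hydrogen-bond donor matters more.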